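The source may hold more compounds than are shown below. What is called first, only, known or untested is meant among the compounds shown, and "the series" means these compounds.

Measured so far in a functional assay on SW-620 cells (Homo sapiens) for cytotoxicity; on this read-out lower numbers stand for stronger inhibition of growth and higher numbers for weaker inhibition of growth
compound 1 `COc1ccc(C2=C(c3ccc(SC)cc3)CC3CCCN3C2=O)cc1OC(=O)CNC(=O)OC(C)(C)C` gives 20000 nM
compound 2 `CSc1ccc(C2=C(c3ccc(C)c(C)c3)C(=O)N3CCCC3C2)cc1` gives 700 nM
compound 3 `CSc1ccc(C2=C(c3ccc(F)c(C)c3)C(=O)N3CCCC3C2)cc1` gives 600 nM

Compound 3 at 600 nM stands level with compound 2 and both lie far under compound 1 at 20000 nM on this scale. The next change leads to compound 4 `COc1ccc(C2=C(c3ccc(SC)cc3)CC3CCCN3C2=O)cc1` with 4-methoxyphenyl in place of 4-fluoro-3-methylphenyl on a double-bonded ring carbon, counted as 4-methoxyphenyl in place of 4-fluoro-3-methylphenyl on a double-bonded ring carbon in full. Going by the values given here, one measured step bears on the leaving group, a 1.2-fold lower number from compound 2 to compound 3 (0.07 log units; within the scatter) for fluoro in place of methyl on an aromatic carbon. Among the compounds with values here, no measured step covers 4-methoxyphenyl at this place. The expectation in this assay is no shift beyond the scatter and the range is kept wide. The expected step is a 1.2-fold lower number from compound 3 to compound 4 (0.08 log units; within the scatter) on this estimate. For compound 4 the estimated value is 500 nM with an expected range from 120 nM to 2500 nM on repeat measurement.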

Compound 4, concentration for 50% growth inhibition: 3000 nM
The estimate for compound 4 lay 6.0-fold (0.78 log units) below the measured number; the measured number lies above the stated range.
By their numbers in this assay, from the lowest: compounds 3 and 2 (each within the scatter of the next); then compound 4; then compound 1.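

Unlike the fluoro for methyl swap, which stayed within the scatter, 4-methoxyphenyl on the double-bonded ring carbon moves this assay beyond it, against both 4-fluoro-3-methylphenyl (a 5.0-fold higher number from compound 3 to compound 4 (0.70 log units; beyond the scatter)) and 3,4-dimethylphenyl (a 4.3-fold higher number from compound 2 to compound 4 (0.63 log units; beyond the scatter)). The group of 12 heavy atoms on the aromatic carbon is also not neutral, since a hydrogen atom in its place gives (a 6.7-fold lower number from compound 1 to compound 4 (0.82 log units; beyond the scatter)). No supporting data explain either shift.

Open, going by these compounds, is how 4-chlorophenyl or a pyridine ring would read at the double-bonded ring carbon. Also open, on these data alone, is how a hydroxyl or an amine would read on the aromatic carbon that carries the group of 12 heavy atoms in compound 1.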